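Notes on an amine-substituted dienone series in Caco-2 cells

The source may hold more compounds than are shown below. What is called first, only, known or untested is meant among the compounds shown, and "the series" means these compounds.

Measured compounds:
compound 1 `C=CCNC(=C\C(=O)/C=C/c1ccc(O)c(OC)c1)/C=C/c1ccc(O)c(OC)c1` — 89%
compound 2 `COc1cc(/C=C/C(=O)/C=C(/C=C/c2ccc(OC(C)=O)c(OC)c2)NCC(C)C)ccc1OC(C)=O` — 96%
compound 3 `CCC(C)NC(=C\C(=O)/C=C/c1ccc(O)cc1)/C=C/c1ccc(O)cc1` — 102%

All three were run in a functional assay on Caco-2 cells (Homo sapiens), read by fluorescence, tested at 1 uM; a higher number here means a weaker effect of the compound at the concentration tested, a lower number a stronger effect. Compound 1 gives the lowest of the three numbers, but compound 2 sits within the scatter of it, so no order between these two can be read; only compound 3 lies beyond the scatter, on the higher side. Compound 1 therefore cannot be called the strongest of the set on these numbers.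

Compound 4 `COc1cc(/C=C/C(=O)/C=C(/C=C/c2ccc(O)c(OC)c2)NCC(C)C)ccc1O` has not yet been measured. It differs from compound 1 by isopropyl in place of vinyl on a saturated chain carbon bound to an amine nitrogen. Among the measured compounds shown here, compound 2 also carries an isobutylamino group, and its value and that of compound 1 are within the scatter of each other; no computed step between those two exists, and no step in this set isolates the amine substituent alone. On that basis the expected step of a number 1 percentage points higher from compound 1 to compound 4 (within the scatter) is none beyond the scatter. Compound 4 is accordingly expected to give 90%, with a likely range from 78% to 102%.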

Compound 4, a percentage reported as activity, at one concentration (the size of the read-out at that concentration, not a potency): 91%
Estimate against measurement, compound 4: 1 percentage points below, within the range that was stated.
By their numbers in this assay, from the lowest: compounds 1, 4, 2 and 3 (each within the scatter of the next, the first and the last beyond it).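

In this assay, among the compounds shown here, allylamino to isobutylamino on the shared core comes out as a number 2 percentage points higher from compound 1 to compound 4 (within the scatter), the only step so far that isolates the amine substituent. Isopropyl in place of vinyl on a saturated chain carbon bound to an amine nitrogen removes the double bond from this chain, yet the two compounds cannot be told apart on this read-out. Nothing measured on these compounds speaks to why they read alike.

The compounds shown leave open whether a longer chain, a benzyl group or a carboxylic acid on the amine nitrogen would move the number beyond the scatter from compound 1. For the compounds shown here, no pair tests this change on another core, so what it does outside compound 1 and compound 4 remains unknown.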